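The source may hold more compounds than are shown below. What is called first, only, known or untested is meant among the compounds shown, and "the series" means these compounds.

Compound 1 `CCN(Cc1cccs1)C(=O)COc1ccc(Cl)cc1` is tested in an assay on HEK293 cells for agonist activity at transient receptor potential cation channel subfamily M member 8 (Homo sapiens), read by fluorescence and calcium flux, with a stated time of 15 min (on this read-out lower numbers stand for an effect already at smaller amounts and higher numbers for an effect only at larger amounts of compound), and gives 39 nM. Among the three compounds measured so far, its number is the second highest: compound 2 `CCN(Cc1cccs1)C(=O)COc1cc(C)ccc1O` gives 24 nM in this assay, and compound 3 `Cc1ccc(OCC(=O)N(Cc2cccs2)C(C)C)cc1` gives 70 nM, both of them within the usual scatter of compound 1. No pair of these compounds differs in just one place, so no single structural step has yet been tied to a change in the read-out. Compound 4 `CCN(Cc1cccs1)C(=O)COc1ccc(C#N)cc1` has not been measured. It differs from compound 1 by cyano in place of chloro on an aromatic carbon. Going by the values given here, with no comparable step on record, the expected step of a 1.3-fold higher number from compound 1 to compound 4 (0.11 log units; within the scatter) is small, not clearly beyond the scatter. Compound 4 is therefore estimated at 50 nM, with a range from 15 nM to 160 nM.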

Compound 4, half-maximal effective concentration: 1990 nM
Estimate against measurement, compound 4: 40-fold (1.60 log units) below, outside the stated range (above it).
By their numbers in this assay, from the lowest: compounds 2, 1 and 3 (each within the scatter of the next, the first and the last beyond it); then compound 4.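

On an aromatic carbon para to a large group, cyano in place of chloro gives a 51-fold higher number from compound 1 to compound 4 (1.71 log units; beyond the scatter) in this assay. Going by these compounds alone, this is the first single-place comparison, and it shows that the read-out is highly sensitive to the group at this position. No measurement on hand accounts for the size of this step.

From the compounds shown here alone, whether other groups at this carbon, such as a methoxy group, an amine or a carboxylic acid, would also raise the number remains open. It is also unknown whether this step would be the same size on compound 2 or compound 3.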